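Ring Swap on the Amide Side Chain of a Ghrelin Antagonist

The source may report more compounds than this note shows. Statements on the series, on what has been measured and on what is new or still open speak of the compounds shown alone.

The account begins with two measured compounds sharing one core. Compound 1 `CN1CCCN(CC(=O)NC2(c3ccc(Cl)c(Cl)c3)C(=O)Nc3cc(Cl)cc(Cl)c32)CC1` carries a 4-methyl-1,4-diazepan-1-yl group on a saturated chain carbon bound to a carbonyl carbon; in an in vitro functional assay on CHO-CREluc cells for antagonist activity at growth hormone secretagogue receptor type 1 (Homo sapiens), read by a luciferase reporter, with a stated time of 4 h (on this read-out higher numbers stand for weaker inhibition and lower numbers for stronger inhibition), compound 1 gives 64 nM. Compound 2 `CN1CCN(CC(=O)NC2(c3ccc(Cl)cc3)C(=O)Nc3cc(Cl)cc(Cl)c32)CC1` differs in more than one place, and in this assay compound 2 gives 72 nM. Compound 1 shows the smaller of the two numbers, but the two values sit within the scatter of each other, so neither can be set apart from the other.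

The step under study leads to compound 3 `C=CCN1CCN(CC(=O)NC2(c3ccc(Cl)c(Cl)c3)C(=O)Nc3cc(Cl)cc(Cl)c32)CC1`. Here the change is 4-allylpiperazin-1-yl in place of 4-methyl-1,4-diazepan-1-yl on a saturated chain carbon bound to a carbonyl carbon. Among the compounds with values here, no measured pair isolates this change, so the expectation rests on the single measured neighbour. The author expects the step of a 1.4-fold higher number from compound 1 to compound 3 (0.15 log units; within the scatter) to stay within the scatter, leaning, if anywhere, toward a slightly higher number. For compound 3 in this assay the estimate is 90 nM, with a range from 35 nM to 250 nM.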

Compound 3, half-maximal inhibitory concentration: 38 nM
Beside the measured number, compound 3's estimate is 2.4-fold (0.37 log units) above it; low and high end bracket the measured number.
By their numbers in this assay, from the lowest: compounds 3, 1 and 2 (each within the scatter of the next).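

In this assay, 4-allylpiperazin-1-yl in place of 4-methyl-1,4-diazepan-1-yl on a saturated chain carbon bound to a carbonyl carbon gives a 1.7-fold lower number from compound 1 to compound 3 (0.23 log units; within the scatter), so the two values cannot be set apart. This is the first pair shown that differs in this one place, and it shows that this place can carry either the seven-membered or the six-membered ring, with its larger substituent, without a step beyond the scatter. No available evidence bears on this result.

The swap alters the ring and the group on it together, so the compounds shown do not separate the two. A 4-allyl-1,4-diazepan-1-yl group would address that question, while a morpholin-4-yl group at this place would test whether the second ring nitrogen matters.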